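Kallikrein-7 series: swapping the anilide meta substituent

The source may hold more compounds than are shown below. What is called first, only, known or untested is meant among the compounds shown, and "the series" means these compounds.

Compound 1 `CNC(=O)c1cccc(NC(=O)CN2C/C(=N/N(C)C)NC[C@@H](Cc3cc(Cl)ccc3OC)C2=O)c1` is the reference point of this short set. Within the data shown here, in an assay on isolated protein for inhibition of kallikrein-7 (Homo sapiens), read by fluorescence, with stated times of 10 min and 30 min (a lower number here means a stronger inhibitor, a higher number a weaker inhibitor), compound 1 gives 940 nM, the lowest of the two numbers measured so far; its nearest neighbour is compound 2 `COc1cccc(NC(=O)CN2C/C(=N/N(C)C)NC[C@@H](Cc3cc(Cl)ccc3OC)C2=O)c1`, which in this assay gives 2700 nM. Among the measured compounds shown here, the single measured step, a 2.9-fold higher number from compound 1 to compound 2 (0.46 log units; beyond the scatter), exchanges the methylcarbamoyl for a methoxy and is the only change seen at that position.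

Compound 3 `COc1ccc(Cl)cc1C[C@@H]1CN/C(=N\N(C)C)CN(CC(=O)Nc2cccc(-c3ccoc3)c2)C1=O` is not yet measured. It differs from compound 1 by furan-3-yl in place of methylcarbamoyl on an aromatic carbon, so the same position that moved between compound 1 and compound 2 is altered again, and the methylcarbamoyl leaves in both cases. The step of a 2.9-fold higher number from compound 1 to compound 2 (0.46 log units; beyond the scatter) is the only one that bears on this change; it was modest and went toward a higher number. The expectation for compound 3 in this assay is therefore a step of similar size in the same direction, a 2.3-fold higher number from compound 1 to compound 3 (0.37 log units; beyond the scatter), with a wide range since a furan-3-yl has not been tried anywhere in the series. The estimate for compound 3 in this assay is 2200 nM, expected to fall between 800 nM and 6000 nM.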

Compound 3, half-maximal inhibitory concentration: 670 nM
Compound 3: the middle estimate sits 3.3-fold (0.52 log units) above what was measured; the whole stated range lies above it.
By their numbers in this assay, from the lowest: compounds 3 and 1 (each within the scatter of the next); then compound 2.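

In this assay a 1.4-fold lower number from compound 1 to compound 3 (0.15 log units; within the scatter) shows that the methylcarbamoyl can leave this aromatic carbon without a shift beyond the scatter, so the rise seen with methoxy cannot be read as a general cost of removing that group. The a 4.0-fold lower number from compound 2 to compound 3 (0.61 log units; beyond the scatter) shows that the group entering this position matters, and among these three compounds it is compound 2 that stands apart, while compound 1 and compound 3 read alike even though the furan-3-yl brings a five-membered aromatic ring and 0 hydrogen-bond donors in place of an open amide with a donor. Nothing available on these compounds explains why furan-3-yl and methylcarbamoyl read alike here while methoxy does not.

The compounds shown leave open whether the match with compound 1 belongs to furan-3-yl itself or extends to other rings at this place, such as a thiophene, a pyridine or a plain phenyl. They also leave open how a carboxylic acid, an amine or a longer amide chain on the same aromatic carbon would read against the shared core.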